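Homologation of the alkyl group across two cores

A few compounds are considered here, and "the series" means these few. Any claim that something is new, unique, unknown or untested is made for them only; others in the source may bear on it.

Measured compounds:
compound 1 `CCn1nc(-c2ccnc(Nc3cccc(S(N)(=O)=O)c3)n2)c2ccccc21` gives 9010 nM
compound 2 `CCCn1nc(-c2ccnc(Nc3cccc(S(N)(=O)=O)c3)n2)c2ccccc21` gives 7950 nM
compound 3 `Cc1nn(-c2ccnc(Nc3cccc(S(N)(=O)=O)c3)n2)c2ncccc12` gives 24800 nM

All numbers come from a functional assay on HCT-116 cells (Homo sapiens) for antiproliferative activity, read by MTT assay, with a stated time of 72 h; a higher number here means a weaker inhibitor of growth, a lower number a stronger inhibitor of growth. Compound 1 and compound 2 share a core; they differ by methyl in place of hydrogen on a saturated chain carbon, two bonds along the chain from an aromatic nitrogen. The step of a 1.1-fold lower number from compound 1 to compound 2 (0.05 log units; within the scatter) is within the scatter. Compound 3 stands on a different core; the difference between the two cores is not broken down here. Compound 3 shows the highest number of the three.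

Compound 4 `CCc1nn(-c2ccnc(Nc3cccc(S(N)(=O)=O)c3)n2)c2ncccc12` is not yet measured. It differs from compound 3 by methyl in place of hydrogen on a saturated chain carbon bound to an aromatic carbon. This is the same kind of change as that from compound 1 to compound 2, not the same: the place differs, a saturated chain carbon bound to an aromatic carbon rather than one two bonds along the chain from an aromatic nitrogen.

Resting on compound 1 and the step of a 1.1-fold lower number from compound 1 to compound 2 (0.05 log units; within the scatter), a small step is expected, a 1.2-fold lower number from compound 3 to compound 4 (0.07 log units; within the scatter). Compound 4 is estimated at 21000 nM, between 8000 nM and 55000 nM.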

Compound 4, concentration for 50% growth inhibition: 65100 nM
Compound 4: middle estimate off by 3.1-fold (0.49 log units), on the low side; the whole stated range lies below it.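

In this assay, methyl to ethyl on the core of compound 3 gives a 2.6-fold higher number from compound 3 to compound 4 (0.42 log units; beyond the scatter), a clear weakening of growth inhibition on this core. The change does not carry over with the same result between the two cores: the same change on two cores in this assay, a 1.1-fold lower number (0.05 log units; within the scatter) from compound 1 to compound 2 and a 2.6-fold higher number (0.42 log units; beyond the scatter) from compound 3 to compound 4, 3.0-fold (0.47 log units) apart, beyond the scatter of two such steps

Core and place of the change differ together between the two pairs, and one pair per core can neither separate those two factors nor set a rule for the series. Open, going by these compounds, is how a longer chain, or an amine, in place of the ethyl of compound 4 would read on this core. Also open, on these data alone, is whether a cyclopropyl group would read the same on both cores.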